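The source may hold more compounds than are shown below. What is called first, only, known or untested is meant among the compounds shown, and "the series" means these compounds.

Growth inhibition was measured in a functional assay on NCI-H226 cells (Homo sapiens) for inhibition (on this read-out higher numbers stand for weaker inhibition of growth and lower numbers for stronger inhibition of growth), and two compounds have been tested so far. Compound 1, with the structure `C=C1CCC[C@H]2[C@](C)(CCC(C)=O)[C@@H](C)CC[C@]12C`, reached only the limit of this assay, > 15000 nM, so no number stands for it. That limit is the one recorded in the limit of > 15000 nM in this assay, at which 1 of the 2 values shown sits. Within the data shown here, compound 2, with the structure `C=C1CCCC(C)(C)C1CC[C@@]1(C)CC[C@H]([C@@H](C)C(=O)O)OO1`, is therefore the sole compound with a measured number: in this assay compound 2 gives 12500 nM, a weak inhibition of growth.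

Compound 3, with the structure `C=C1CCCC(C)(C)C1CC[C@]1(C)CC[C@@H]([C@@H](C)C(=O)O)OO1`, has exactly the same atoms and bonds as compound 2 and differs only in configuration: the two compounds have the same atoms and bonds; at least one stereo element is drawn with a configuration in one of them and without one in the other: 2 of 4 stereo elements differ; a stereocentre at a saturated ring carbon is drawn S in compound 2 and R in compound 3; a stereocentre at a saturated ring carbon is drawn R in compound 2 and S in compound 3. Among the measured compounds shown here, no pair of measured compounds separated by a single change has been compared yet, so there is no measured step to lean on. A change of configuration alone, with the parent sitting this far toward weak inhibition, is expected to move the number little; the step from compound 2 to compound 3 is estimated at a 1.0-fold lower number from compound 2 to compound 3 (0.02 log units; within the scatter), within the usual scatter. Compound 3 is thus expected to give about 12000 nM in this assay, with a range from 4000 nM to 30000 nM, and a real chance that only a limit is reported.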

Compound 3, concentration for 50% growth inhibition: > 10000 nM
Compound 3: only a limit was reported; the forecaster's own chance of this, stated with the estimate: 40%; the middle value is on the limit's open side.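

The step from compound 2 to compound 3 cannot be read, because compound 3 is recorded in this assay only as a limit and not as a number: the limit of > 10000 nM in this assay, at which 1 of the 3 values shown sits.

The compounds shown leave open whether the change of configuration at the two saturated ring carbons alters growth inhibition at all, and by how much.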